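The source may report more compounds than this note shows. Statements on the series, on what has been measured and on what is new or still open speak of the compounds shown alone.

Measured so far in a functional assay on DLD-1 cells (Homo sapiens) for cytotoxicity, with a stated time of 48 h; a lower number here means a stronger inhibitor, a higher number a weaker inhibitor:
compound 1, `Cc1ccc2c(=O)cc(/C=C/[S+](C)[O-])oc2c1`: 7000 nM
compound 2, `CC(C)CC(=O)Oc1ccc2oc(/C=C/[S+](C)[O-])cc(=O)c2c1`: 6100 nM
compound 3, `C[S+]([O-])/C=C/c1cc(=O)c2cc(F)ccc2o1`: 7000 nM

All three numbers lie within the scatter of one another. Compound 3 gives the same number as compound 1 at the digits shown, and the only one-place step among the measured compounds, a 1.1-fold higher number from compound 2 to compound 3 (0.06 log units; within the scatter), is itself within the scatter. On these numbers compound 3 is neither set apart from compound 1 nor from compound 2.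

Compound 4, `C[S+]([O-])/C=C/c1cc(=O)c2cc(OC(=O)C(C)(C)C)ccc2o1`, differs from compound 3 by ((tert-butyl)carbonyl)oxy in place of fluoro on an aromatic carbon. Among the measured compounds shown here, the one step that bears on this change is the move between compound 2 and compound 3, where an (isobutylcarbonyl)oxy group gave way to fluoro on the same aromatic carbon with a shift of a 1.1-fold higher number from compound 2 to compound 3 (0.06 log units; within the scatter). Compound 4 runs that exchange the other way, with a ((tert-butyl)carbonyl)oxy group entering in place of fluoro. Nothing in the series suggests a step beyond the scatter in either direction for this assay. Compound 4 is therefore expected at 6500 nM, range 3000 nM to 14000 nM, corresponding to an expected step of a 1.1-fold lower number from compound 3 to compound 4 (0.03 log units; within the scatter).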

Compound 4, half-maximal inhibitory concentration: 8000 nM
Compound 4: middle estimate off by 1.2-fold (0.09 log units), on the low side, within the range that was stated.
By their numbers in this assay, from the lowest: compounds 2, 1, 3 and 4 (each within the scatter of the next).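

In this assay the aromatic carbon carries either fluoro or ((tert-butyl)carbonyl)oxy with no step beyond the scatter (a 1.1-fold higher number from compound 3 to compound 4 (0.06 log units; within the scatter)). The earlier compounds shown here covered only an exchange between fluoro and (isobutylcarbonyl)oxy at this carbon, whereas compound 2 and compound 4 now give a change within the acyloxy group itself, tert-butyl in place of isobutyl on a carbonyl carbon, and this also stays within the scatter (a 1.3-fold higher number from compound 2 to compound 4 (0.12 log units; within the scatter)). No evidence is available to explain why these numbers stay so close.

Open, from the compounds shown here alone, is whether an amine or a carboxylic acid on this aromatic carbon would give a step beyond the scatter. Also open, going by these compounds, is whether a longer chain on the carbonyl carbon would do so.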